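Pyridin-4-yl Variant and Its Expected Cell Effect

This account rests on a few compounds, and the source may have more. Where it says the series, first, only, none or still open, it means among the compounds named here.

Compound 3 `Nc1ccccc1NC(=O)c1ccc(CSC(=S)N2CCN(Cc3cccnc3)CC2)cc1` holds the highest of the three numbers in a functional assay on HeLa cells (Homo sapiens) for antiproliferative activity, read by CCK-8 assay, with a stated time of 72 h, tested at 2 uM (a higher number here means a stronger effect of the compound at the concentration tested, a lower number a weaker effect), giving 69.7%; compound 1 `Nc1ccccc1NC(=O)c1ccc(CSC(=S)N2CCN(c3cccnc3)CC2)cc1` gives 66.2% and compound 2 `Nc1ccccc1NC(=O)c1ccc(CSC(=S)N2CCN(c3ccc(F)cc3)CC2)cc1` gives 60.8%, and both gaps to compound 3 lie within the scatter. Compound 4 `Nc1ccccc1NC(=O)c1ccc(CSC(=S)N2CCN(c3ccncc3)CC2)cc1` differs from compound 3 in one place: pyridin-4-yl in place of (pyridin-3-yl)methyl on an amine nitrogen in a ring The closest guide is a number 3.5 percentage points higher from compound 1 to compound 3 (within the scatter), which exchanged pyridin-3-yl for (pyridin-3-yl)methyl on the same nitrogen; a number 5.4 percentage points lower from compound 1 to compound 2 (within the scatter) and a number 8.9 percentage points higher from compound 2 to compound 3 (within the scatter) show that other exchanges at this nitrogen also stayed within the scatter. Compound 4 is therefore expected to show no step beyond the scatter, a number 4.7 percentage points lower from compound 3 to compound 4 (within the scatter). The estimate for compound 4 is 65%, with a range from 50% to 78%.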

Compound 4, a percentage reported as inhibition, at one concentration (the size of the read-out at that concentration, not a potency): 77%
Compound 4: middle estimate off by 12 percentage points, on the low side; measured number inside the range.
By their numbers in this assay, from the lowest: compounds 2, 1, 3 and 4 (each within the scatter of the next, the first and the last beyond it).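

For the compounds shown here, exchanging pyridin-3-yl for pyridin-4-yl on the amine nitrogen in the ring gives a number 10.8 percentage points higher from compound 1 to compound 4 (beyond the scatter) in this assay, and exchanging 4-fluorophenyl for pyridin-4-yl gives a number 16.2 percentage points higher from compound 2 to compound 4 (beyond the scatter); these are the first steps at this position to pass the scatter. Against (pyridin-3-yl)methyl the exchange gives a number 7.3 percentage points higher from compound 3 to compound 4 (within the scatter), so those two compounds cannot be told apart. Nothing measured here explains these steps. From the compounds shown here alone, whether pyridin-2-yl or (pyridin-4-yl)methyl on this nitrogen would match pyridin-4-yl remains open.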